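The compounds below may be only part of what the source reports. "The series", "measured", "known", "first", "only" and "open" are said of these compounds alone.

Working notes, bile acid receptor agonist series.

Compound 3 `CC(C)n1nc(C(=O)O)cc1C1CC1c1ccc(OCc2c(-c3c(Cl)cccc3Cl)noc2C2CC2)cc1Cl` gives 6 nM in an assay on HEK293 cells for agonist activity at Bile acid receptor (Homo sapiens) (on this read-out higher numbers stand for an effect only at larger amounts of compound and lower numbers for an effect already at smaller amounts), and stands lowest of the three measured numbers. Going by the values given here, compound 1 `O=C(O)c1cccc([C@H]2C[C@@H](c3ccc(OCc4c(-c5c(Cl)cccc5Cl)noc4C4CC4)cc3Cl)C2)c1` gives 92 nM in this assay, and compound 2 `CCO[C@]1(c2ccc(OCc3c(-c4c(Cl)cccc4Cl)noc3C3CC3)cc2Cl)C[C@H](c2cccc(C(=O)O)c2)C1` gives 220 nM; the only measured single-point step, a 2.4-fold higher number from compound 1 to compound 2 (0.38 log units; beyond the scatter), concerns a change on the saturated ring of the core and not the acid-bearing aryl group. Compound 4 `O=C(O)c1ccc(C2CC2c2ccc(OCc3c(-c4c(Cl)cccc4Cl)noc3C3CC3)cc2Cl)cn1` differs from compound 3 by 6-carboxypyridin-3-yl in place of 3-carboxy-1-isopropyl-1H-pyrazol-5-yl on a saturated ring carbon. Among the compounds with values here, no measured step follows this kind of exchange, so the expectation rests on the observation that the acid-bearing aryl group varies widely across the set, with compound 3 at 6 nM against compound 1 at 92 nM. A moderate rise in the number is expected for compound 4, in the sense of a 2.5-fold higher number from compound 3 to compound 4 (0.40 log units; beyond the scatter), but the range must be wide. Compound 4 is estimated at 15 nM in this assay, with a range from 4 nM to 60 nM.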

Compound 4, half-maximal effective concentration: 57 nM
Estimate against measurement, compound 4: 3.8-fold (0.58 log units) below; the range from low to high includes it.
By their numbers in this assay, from the lowest: compound 3; then compounds 4 and 1 (each within the scatter of the next); then compound 2.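

On a saturated ring carbon of the three-membered ring, the group carrying the carboxylic acid clearly affects the read-out in this assay: 6-carboxypyridin-3-yl in place of 3-carboxy-1-isopropyl-1H-pyrazol-5-yl gives a 9.5-fold higher number from compound 3 to compound 4 (0.98 log units; beyond the scatter). Going by these compounds alone, the earlier single-point step concerned a different change on the saturated ring, so this is the first direct reading of an exchange of the acid-bearing group. The exchange alters the aromatic ring and removes the isopropyl group together, and no measurement shown bears on the reason for the rise.

Going by these compounds, it remains open whether the ring or the isopropyl group accounts for the step. On these data alone, how a methyl in place of the isopropyl, or a primary amide in place of the carboxylic acid, would read at this position also remains open.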